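From 4-chlorophenyl to 3-methylphenyl on the shared core

This account rests on a few compounds, and the source may have more. Where it says the series, first, only, none or still open, it means among the compounds named here.

In (an ADME assay on HepG2 cells (Homo sapiens) for cytotoxicity, read by MTT assay, with a stated time of 48 h; on this read-out lower numbers stand for higher toxicity in this test and higher numbers for lower toxicity in this test) compound 3 (`C#CCN(c1nc(-c2ccc(Cl)cc2)no1)C1CCCCC1`) gives the lowest number of the three measured (41.3 ug/mL), against compound 1 (`C#CCN(c1nc(-c2ccccc2)no1)C1CCCCC1`) at (109 ug/mL) and compound 2 (`C#CCN(c1nc(-c2ccc(C)cc2)no1)C1CCCCC1`) at (91.9 ug/mL). Compound 4 (`C#CCN(c1nc(-c2cccc(C)c2)no1)C1CCCCC1`) remains unmeasured, and it carries 3-methylphenyl in place of 4-chlorophenyl on an aromatic carbon. Methyl in place of hydrogen stayed within the scatter (a 1.2-fold lower number from compound 1 to compound 2 (0.07 log units; within the scatter)), while chloro in place of hydrogen was a modest step down (a 2.6-fold lower number from compound 1 to compound 3 (0.42 log units; beyond the scatter)). For the measured compounds named here, the closest precedent is chloro in place of methyl, also modest (a 2.2-fold lower number from compound 2 to compound 3 (0.35 log units; beyond the scatter)). Going by the values given here, no measured compound yet carries 3-methylphenyl, so a modest rise, reversing that step, is only expected (a 2.2-fold higher number from compound 3 to compound 4 (0.34 log units; beyond the scatter)). Compound 4 is estimated at (90 ug/mL), within a range from (50 ug/mL) to (160 ug/mL).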

Compound 4, half-maximal cytotoxic concentration: 44.4 ug/mL
Beside the measured number, compound 4's estimate is 2.0-fold (0.31 log units) above it; measured number below the stated range.
By their numbers in this assay, from the lowest: compounds 3 and 4 (each within the scatter of the next); then compounds 2 and 1 (each within the scatter of the next).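

Where the methyl sits on the phenyl now counts in this assay: 3-methylphenyl in place of 4-methylphenyl lowers the number (a 2.1-fold lower number from compound 2 to compound 4 (0.32 log units; beyond the scatter)), and methyl in place of hydrogen, within the scatter as 4-methylphenyl, is a modest step down as 3-methylphenyl (a 2.5-fold lower number from compound 1 to compound 4 (0.39 log units; beyond the scatter)). The 3-methylphenyl group also stands level with 4-chlorophenyl (a 1.1-fold higher number from compound 3 to compound 4 (0.03 log units; within the scatter)), so the two groups cannot be told apart here. No evidence given here accounts for these steps.

On these data alone, whether 3-chlorophenyl would give a still lower number stays open. So does what an amine or a carboxylic acid on the phenyl would do.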